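The source may report more compounds than this note shows. Statements on the series, on what has been measured and on what is new or still open speak of the compounds shown alone.

In an assay on striatum for inhibition of sodium-dependent dopamine transporter (Rattus norvegicus) (on this read-out lower numbers stand for stronger inhibition and higher numbers for weaker inhibition), compound 1 `Oc1cccc(CN[C@H]2CC[C@@H](C(c3ccccc3)c3ccccc3)OC2)c1` gives 31.3 nM, compound 2 `c1ccc(C(c2ccccc2)[C@@H]2CC[C@H](NCc3ccc[nH]3)CO2)cc1` gives 43.2 nM and compound 3 `c1ccc(C(c2ccccc2)[C@@H]2CC[C@H](NCc3ccco3)CO2)cc1` gives 110 nM, the highest of the three numbers, with both other compounds beyond the scatter from it. The steps of a 3.5-fold higher number from compound 1 to compound 3 (0.55 log units; beyond the scatter) and a 2.5-fold higher number from compound 2 to compound 3 (0.41 log units; beyond the scatter) each exchange the group on a saturated chain carbon bound to an amine nitrogen, while the step of a 1.4-fold higher number from compound 1 to compound 2 (0.14 log units; within the scatter) stays within the scatter. Compound 4 `c1ccc(C(c2ccccc2)[C@@H]2CC[C@H](NCc3cccnc3)CO2)cc1` differs from compound 3 by pyridin-3-yl in place of furan-2-yl on a saturated chain carbon bound to an amine nitrogen. Since both exchanges away from furan-2-yl lowered the number, a further exchange of furan-2-yl for a six-membered aromatic ring is expected to lower it again by a modest step. For compound 4 the estimate is 50 nM, with a range from 20 nM to 150 nM. This corresponds to an expected step of a 2.2-fold lower number from compound 3 to compound 4 (0.34 log units; beyond the scatter).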

Compound 4, inhibition constant: 145 nM
Compound 4: middle estimate off by 2.9-fold (0.46 log units), on the low side; the measured number falls inside the stated range.
By their numbers in this assay, from the lowest: compounds 1 and 2 (each within the scatter of the next); then compounds 3 and 4 (each within the scatter of the next).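

At this position, on a saturated chain carbon bound to an amine nitrogen, pyridin-3-yl and furan-2-yl cannot be told apart in this assay (with a 1.3-fold higher number from compound 3 to compound 4 (0.12 log units; within the scatter)), so a six-membered aromatic ring with one hetero atom does not by itself bring the number down. The steps of a 3.4-fold higher number from compound 2 to compound 4 (0.53 log units; beyond the scatter) and a 4.6-fold higher number from compound 1 to compound 4 (0.67 log units; beyond the scatter) put pyridin-3-yl with furan-2-yl, apart from 1H-pyrrol-2-yl and 3-hydroxyphenyl. Nothing available explains this split into two pairs. Open, going by these compounds, is where an unsubstituted phenyl or a thiophen-2-yl would fall relative to these two pairs.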